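The source may hold more compounds than are shown below. What is called first, only, known or untested is meant among the compounds shown, and "the series" means these compounds.

Measured so far:
compound 1, `O=c1sc2cc(N(S(=O)(=O)c3ccccc3)S(=O)(=O)c3ccccc3)ccc2n1CCN1CCCC1`, 20%
compound 2, `O=c1sc2cc(NS(=O)(=O)c3ccccc3)ccc2n1CCN1CCCC1`, 11%
compound 3, `CN(C)CCn1c(=O)sc2cc(NS(=O)(=O)c3ccc4ccccc4c3)ccc21`, 22%

All three were tested in an assay on HEK293 cells for displacement of a labelled ligand from 5-hydroxytryptamine receptor 6 (Homo sapiens), read by radioligand binding, with a stated time of 60 min, tested at 100 nM; on this read-out higher numbers stand for more inhibition at the one concentration tested (going by the name of the read-out) and lower numbers for less inhibition. Compound 3 gives a number that lies within the scatter of compound 1 and beyond the scatter above compound 2, so it sits at the upper end of the three values without being set apart from compound 1.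

Going by the values given here, the only single-point step measured is a number 9 percentage points lower from compound 1 to compound 2 (within the scatter). It concerns the sulfonamide nitrogen and nothing else, and it stays within the scatter. Compound 2 and compound 3 differ in two places at once, so their values can only be read side by side: compound 2 gives 11% and compound 3 gives 22%.

Compound 4, `O=c1sc2cc(NS(=O)(=O)c3ccc4ccccc4c3)ccc2n1CCN1CCCCC1`, differs from compound 3 by piperidin-1-yl in place of dimethylamino on a saturated chain carbon, two bonds along the chain from an aromatic nitrogen. Among the compounds with values here, no measured step touches this part of the molecule, so there is nothing in the data that points to a change in either direction. On that basis compound 4 is expected to give about 22% in this assay, with a range from 5% to 40%. The expected step is no change at the digits printed from compound 3 to compound 4 (within the scatter), that is, no change beyond the scatter.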

Compound 4, a percentage reported as inhibition, at one concentration (the size of the read-out at that concentration, not a potency): 4%
Compound 4: the middle estimate sits 18 percentage points above what was measured; the measured number lies below the stated range.
By their numbers in this assay, from the lowest: compounds 4, 2, 1 and 3 (each within the scatter of the next, the first and the last beyond it).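

In this assay, going by these compounds alone, the change at the end of the chain gives a number 18 percentage points lower from compound 3 to compound 4 (beyond the scatter), the first measured step to touch this part of the molecule. Unlike the step on the sulfonamide nitrogen, a number 9 percentage points lower from compound 1 to compound 2 (within the scatter), it lies beyond the scatter, so the group on this saturated chain carbon, two bonds along the chain from an aromatic nitrogen, is not a free choice in this pair. What differs is the shape of the amine and its count of heavy atoms, 3 leaving and 6 entering with one six-membered non-aromatic ring, while the counted hydrogen-bond donors and acceptors stay the same, and nothing available explains why the number falls.

This single pair cannot separate the effect of the ring from that of the added heavy atoms, and an open-chain diethylamino group or a morpholin-4-yl ring would be the natural groups to tell these apart. It also leaves open whether a longer chain, such as 3-(dimethylamino)propyl, would keep the number of compound 3 or whether the same swap would give a similar step on a different sulfonamide.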